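Cyclopentyl to Cyclohexyl: a Small Step Expected

This account rests on a few compounds, and the source may have more. Where it says the series, first, only, none or still open, it means among the compounds named here.

Compound 1, `COc1cccc(-c2cc(=O)c3cc(OCCCCCCN4CCC(O)CC4)ccc3o2)c1`: 76 nM
Compound 2, `O=c1cc(C2CCCC2)oc2ccc(OCCCCCCN3CCC(O)CC3)cc12`: 51 nM

Of the compounds shown here, two have been measured in an assay on isolated protein (Cavia porcellus) with Sigma non-opioid intracellular receptor 1 (Homo sapiens) as the target, read by radioligand binding; a higher number here means a weaker inhibitor, a lower number a stronger inhibitor. Compound 1 gives 76 nM and compound 2 gives 51 nM. Compound 2 has the lower of the two numbers, but the gap to compound 1 is within the scatter, so the two cannot be told apart on these data. Among the compounds with values here, the one measured step, a 1.5-fold lower number from compound 1 to compound 2 (0.17 log units; within the scatter), swapped an aromatic ring for a saturated five-membered one and changed little.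

Compound 3, `O=c1cc(C2CCCCC2)oc2ccc(OCCCCCCN3CCC(O)CC3)cc12`, has not yet been measured. It differs from compound 2 in one place: cyclohexyl in place of cyclopentyl on an aromatic carbon. Within the data shown here, the only step that bears on this change is a 1.5-fold lower number from compound 1 to compound 2 (0.17 log units; within the scatter), which shows that the group next to the ring oxygen tolerated a large swap with no shift beyond the scatter. Enlarging a saturated ring by one carbon is a smaller change, so no step beyond the scatter is expected. Compound 3 is therefore estimated at 45 nM, with a range from 20 nM to 110 nM, which corresponds to an expected step of a 1.1-fold lower number from compound 2 to compound 3 (0.05 log units; within the scatter).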

Compound 3, half-maximal inhibitory concentration: 88 nM
Compound 3: the middle estimate sits 2.0-fold (0.29 log units) below what was measured; low and high end bracket the measured number.
By their numbers in this assay, from the lowest: compounds 2, 1 and 3 (each within the scatter of the next).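

In this assay, adding one carbon to the saturated ring gives a 1.7-fold higher number from compound 2 to compound 3 (0.24 log units; within the scatter) and so stays within the scatter: at this position, on an aromatic carbon next to the ring oxygen, cyclopentyl and cyclohexyl cannot be told apart. Within the data shown here, replacing 3-methoxyphenyl with cyclohexyl gives a 1.2-fold higher number from compound 1 to compound 3 (0.06 log units; within the scatter) and is also within the scatter, so an aromatic ring and two saturated rings of different sizes have now been compared here, and no step among the three compounds goes beyond the scatter. The result therefore extends the earlier finding from one swap to a small set of ring groups, but no outside information accounts for the small differences in these numbers.

Going by these compounds, all three groups at this position are rings made up only of carbon atoms, apart from the methoxy oxygen, so it remains open how a much smaller group such as methyl, or a ring containing nitrogen such as pyridyl, would read here. The rest of the molecule is the same in all three compounds, so it is also unknown whether this pattern would hold with a shorter chain.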